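Swapping a Methyl for Naphthalenyl on a Sulfonamide Ring

The compounds below may be only part of what the source reports. "The series", "measured", "known", "first", "only" and "open" are said of these compounds alone.

Of the compounds shown here, three sharing one core have been measured in a functional assay on DLD-1 cells (Homo sapiens) for antiproliferative activity, read by CellTiter-Glo, with a stated time of 72 h; on this read-out lower numbers stand for stronger inhibition and higher numbers for weaker inhibition. Compound 1 `CC1CCN(C2CCN(S(=O)(=O)c3cccc(C(F)(F)F)c3)CC2)CC1` carries a trifluoromethyl group on its aromatic ring; in this assay it reaches only the limit of > 5000 nM, which is not a number (the limit of > 5000 nM in this assay, at which 1 of the 3 values shown sits). Compound 2 `CC1CCN(C2CCN(S(=O)(=O)c3cccc(N)c3)CC2)CC1` carries an amino group at the same place and gives 3400 nM. Compound 3 `Cc1cccc(S(=O)(=O)N2CCC(N3CCC(C)CC3)CC2)c1` carries a methyl group there and gives 25 nM, the lowest of the two numbers shown; the nearest is compound 2, and the step of a 140-fold lower number from compound 2 to compound 3 (2.13 log units; beyond the scatter) is large, as is an at least 200-fold lower number from compound 1 to compound 3 (2.30 log units; beyond the scatter). The step of an at least 1.4-fold lower number from compound 1 to compound 2 (0.16 log units; that floor lies within the scatter) sits within the scatter.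

Compound 4 `CC1CCN(C2CCN(S(=O)(=O)c3cccc(-c4ccc5ccccc5c4)c3)CC2)CC1` is not yet measured. The change from compound 3 is naphthalen-2-yl in place of methyl on an aromatic carbon, placed on an aromatic carbon of a six-membered aromatic ring of carbon only, meta to a large group. Among the measured compounds shown here, no measured step puts a large aryl group at this position; the measured steps only show that the group on this ring shifts the number strongly. Since compound 3 is already the lowest, a step of a 12-fold higher number from compound 3 to compound 4 (1.08 log units; beyond the scatter) toward a higher number is expected, with wide uncertainty. Compound 4 is estimated at 300 nM, within a range of 30 nM to 3000 nM.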

Compound 4, half-maximal inhibitory concentration: 2 nM
Estimate against measurement, compound 4: 150-fold (2.18 log units) above; measured number below the stated range.
By their numbers in this assay, from the lowest: compound 4; then compound 3; then compound 2. At a limit, above all of these: compound 1.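

In this assay, naphthalen-2-yl gives a 13-fold lower number from compound 3 to compound 4 (1.10 log units; beyond the scatter), which shows that this position on the aromatic ring tolerates a group of 10 heavy atoms and 2 six-membered aromatic rings, and that such a group can lower the number further than methyl does. The earlier compounds shown here held only single substituents of few atoms here, so they could not show this; the change also adds no hydrogen-bond donor or acceptor, so the drop does not depend on gaining either. Against the other two groups the gaps are wider still, with a 1700-fold lower number from compound 2 to compound 4 (3.23 log units; beyond the scatter) and an at least 2500-fold lower number from compound 1 to compound 4 (3.39 log units; beyond the scatter), though this last step rests on a limit and not on a number: the limit of > 5000 nM in this assay, at which 1 of the 4 values shown sits.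

Among the compounds shown here, with only one large aromatic group, it stays open whether the gain needs both rings of naphthalen-2-yl, or whether a single phenyl ring or a longer alkyl chain at this position would do as well. The compounds also leave open why the number falls, and whether a phenyl ring carrying an amine or a carboxylic acid would keep the gain.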